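The compounds below may be only part of what the source reports. "The series", "measured", "known", "first", "only" and "open" are said of these compounds alone.

Three compounds of the series have so far been run in a functional assay on HepG2 cells (Homo sapiens) for inhibition, read by MTT assay, with a stated time of 48 h, tested at 10 uM; a higher number here means more inhibition of growth at the concentration tested, a lower number less inhibition of growth. Compound 1 `C#CCOc1ccc(/C=C/C(=O)c2ccc(Br)cc2)cc1` gives 22%, compound 2 `C#CCOc1ccc(/C=C/C(=O)c2ccc([N+](=O)[O-])cc2)cc1` gives 27%, and compound 3 `O=C(/C=C/c1ccc(OCc2cn(Cc3ccccc3Br)nn2)cc1)c1ccc(Br)cc1` gives 34%. Compound 3 holds the highest of the three numbers; its gap to compound 2 lies within the scatter, its gap to compound 1 beyond it. Within the data shown here, the only step between measured compounds that differ in a single place, a number 5 percentage points higher from compound 1 to compound 2 (within the scatter), concerns a different part of the shared core and does not rise above the scatter.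

Compound 4 `O=C(/C=C/c1ccc(OCc2cn(Cc3ccc(Br)cc3)nn2)cc1)c1ccc(Br)cc1` is the next member to be tested. It differs from compound 3 in one place: 4-bromophenyl in place of 2-bromophenyl on a saturated chain carbon bound to an aromatic nitrogen. Among the measured compounds shown here, none of the measured steps touches this part of the structure; the nearest comparison is the one from compound 1 to compound 2, which alters a different position and was itself within the scatter. No step beyond the scatter is therefore expected in this assay for compound 4, in either direction. The value of compound 4 in this assay is estimated at 33%, between 20% and 46%, which means an expected step of a number 1 percentage points lower from compound 3 to compound 4 (within the scatter).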

Compound 4, percent growth inhibition at one concentration: 22%
For compound 4 the middle estimate is 11 percentage points above the measured one; low and high end bracket the measured number.
By their numbers in this assay, from the lowest: compounds 1, 4, 2 and 3 (each within the scatter of the next, the first and the last beyond it).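

In this assay, the exchange of 2-bromophenyl for 4-bromophenyl on a saturated chain carbon bound to an aromatic nitrogen gives a number 12 percentage points lower from compound 3 to compound 4 (beyond the scatter). Among these compounds, the two groups have the same atoms and the same counts under comparison, so the pair shows that this position responds to a rearrangement of the group alone, with no change in its composition, and this is the first single-place step to pass beyond the scatter, whereas a number 5 percentage points higher from compound 1 to compound 2 (within the scatter) concerns a different part of the structure. Nothing at hand bears on the reason for this step.

This single pair leaves open how a phenyl without bromine, or a group of another kind at the same place, such as an amine, a carboxylic acid or a longer chain, would read in this assay. Also open, as far as these compounds go, is whether the step from 2-bromophenyl to 4-bromophenyl would hold with nitro in place of bromo on the aromatic carbon of the other end of the shared core, since both compounds of this pair carry bromo there.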